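The source may hold more compounds than are shown below. What is called first, only, known or untested is meant among the compounds shown, and "the series" means these compounds.

The measured compounds:

- compound 1, `CCN(CC)Cc1cc(Nc2nc3ccccc3n2Cc2ccc(C(F)(F)F)cc2)ccc1O`, 17500 nM
- compound 2, `CCN(CC)Cc1cc(Nc2nc3ccccc3[nH]2)ccc1O`, > 50000 nM
- compound 3, `Cc1cc(CNC(C)(C)C)c(O)c(Nc2nc3cc(F)c(F)cc3[nH]2)c1`, 16700 nM

In an ADME assay on CHO cells (Cricetulus griseus) for inhibition, read by MTT assay (on this read-out lower numbers stand for stronger inhibition and higher numbers for weaker inhibition), compound 1 gives 17500 nM. For compound 2 the read-out in this assay is not a number but a limit of the assay, > 50000 nM, which is the limit of > 50000 nM in this assay, at which 1 of the 3 values shown sits. Compound 1 and compound 2 differ in one place only, (4-(trifluoromethyl)benzyl in place of hydrogen on an aromatic nitrogen), and the step is an at least 2.8-fold lower number from compound 2 to compound 1 (0.45 log units; beyond the scatter). Compound 3 gives 16700 nM in this assay, a value that sits within the usual scatter of the value of compound 1, so the two cannot be told apart. How the core of compound 3 differs from the core of compound 2 is not broken down here.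

Compound 4, `Cc1cc(CNC(C)(C)C)c(O)c(Nc2nc3cc(F)c(F)cc3n2Cc2ccc(C(F)(F)F)cc2)c1`, has not yet been measured in this assay. Going by the values given here, it differs from compound 3 by 4-(trifluoromethyl)benzyl in place of hydrogen on an aromatic nitrogen, which is the same change, at the same kind of place, as the one that turned compound 2 into compound 1. From compound 3 to compound 4 a step of about a 3.0-fold lower number from compound 3 to compound 4 (0.48 log units; beyond the scatter) is expected, because the same change gave an at least 2.8-fold lower number from compound 2 to compound 1 (0.45 log units; beyond the scatter); that earlier step is only a bound, since the value of compound 2 is a limit, so the size carries uncertainty. The estimate for compound 4 in this assay is 5500 nM, expected to fall between 2000 nM and 16000 nM.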

Compound 4, half-maximal inhibitory concentration: 10000 nM
Compound 4: middle estimate off by 1.8-fold (0.26 log units), on the low side; measured number inside the range.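

In this assay, putting 4-(trifluoromethyl)benzyl in place of hydrogen on the aromatic nitrogen of compound 3 gives a 1.7-fold lower number from compound 3 to compound 4 (0.22 log units; within the scatter), so on this core the change leaves no effect that can be told apart from the ordinary spread of repeated measurements. Whether this really differs from what the same change did on the other core stays undecided: the same change on two cores in this assay, an at least 2.8-fold lower number (0.45 log units; beyond the scatter) from compound 2 to compound 1 and a 1.7-fold lower number (0.22 log units; within the scatter) from compound 3 to compound 4; the limit leaves it open whether they differ The result shows that a clear step on one core did not reappear as a clear step on the other, but it does not show that the true size of the change depends on the core, and the earlier step has no fixed size, as compound 2 sits at a limit of the assay and not at a number: the limit of > 50000 nM in this assay, at which 1 of the 4 values shown sits.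

The compounds shown leave open how other groups on the same nitrogen would read, such as a plain benzyl, a methyl or a longer alkyl chain, or a benzyl carrying an amine or a carboxylic acid. On these data alone, the cores of compound 2 and compound 3 also differ in more than one place, so which part of the core might matter for this change remains open.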